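This account rests on a few compounds, and the source may have more. Where it says the series, first, only, none or still open, it means among the compounds named here.

Compound 2, `Cc1ccccc1-c1nc2c(NC3CCCC3)ncnc2n1C`, gives 55 nM in an assay on CHO cells for displacement of a labelled ligand from adenosine receptor A1 (Homo sapiens), read by scintillation counting, with a stated time of 3 h (on this read-out lower numbers stand for stronger inhibition and higher numbers for weaker inhibition), the highest of the three numbers measured. Compound 1, `Cn1c(-c2ccccc2)nc2c(NC3CCCC3)ncnc21`, gives 2.8 nM, and compound 3, `Cn1c(-c2ccccc2)nc2c(NC3CCC3)ncnc21`, gives 3.2 nM; the step of a 1.1-fold higher number from compound 1 to compound 3 (0.06 log units; within the scatter) lies within the scatter, whereas the step of a 20-fold higher number from compound 1 to compound 2 (1.29 log units; beyond the scatter) is large. Compound 4, `Cn1c(-c2ccccc2Cl)nc2c(NC3CCCC3)ncnc21`, has not been measured; it differs from compound 2 by chloro in place of methyl on an aromatic carbon. Within the data shown here, the only step that bears on this change is the one from compound 1 to compound 2, which shows that a methyl on that aromatic carbon costs much. Among the measured compounds shown here, no measured pair shows chloro there, so the estimate rests on compound 2 alone. The step of a 1.6-fold lower number from compound 2 to compound 4 (0.20 log units; within the scatter) is expected to stay within the scatter. Compound 4 is therefore estimated at 35 nM, with a range from 8 nM to 150 nM.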

Compound 4, inhibition constant: 37 nM
For compound 4 the middle estimate is 1.1-fold (0.02 log units) below the measured one; the measured number falls inside the stated range.
By their numbers in this assay, from the lowest: compounds 1 and 3 (each within the scatter of the next); then compounds 4 and 2 (each within the scatter of the next).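

Chloro and methyl on this aromatic carbon, ortho to a large group, cannot be told apart here: the step (a 1.5-fold lower number from compound 2 to compound 4 (0.17 log units; within the scatter)) lies within the scatter. Chloro in place of hydrogen carries a large cost (a 13-fold higher number from compound 1 to compound 4 (1.12 log units; beyond the scatter)), so the loss seen with methyl is not confined to methyl. The compounds shown leave open whether a methoxy group, an amine or a carboxylic acid on this carbon would give a similar loss. They also leave open how chloro would fare elsewhere on the six-membered aromatic ring. No evidence on the reason for these results is available.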